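Pentan-3-yl replacing 2-fluorophenyl: from compound 3 to compound 4

The source may hold more compounds than are shown below. What is called first, only, known or untested is meant among the compounds shown, and "the series" means these compounds.

Compound 3 `COc1ccc(C(=O)/C(=C/c2ccccc2F)CCOC(C)=O)cc1` reaches only a limit in a functional assay on MCF7 cells (Homo sapiens) for inhibition, read by XTT assay, with a stated time of 48 h (a higher number here means a weaker inhibitor, a lower number a stronger inhibitor), where compound 3 gives > 100000 nM. Compound 1 `COc1ccc(C(=O)/C(=C/c2ccccc2F)COC(C)=O)cc1` gives 30000 nM in this assay, and compound 2 `CCC(/C=C(\COC(C)=O)C(=O)c1ccc(OC)cc1)CC` gives 13700 nM. The change leading to compound 4 `CCC(/C=C(\CCOC(C)=O)C(=O)c1ccc(OC)cc1)CC` is pentan-3-yl in place of 2-fluorophenyl on a double-bonded chain carbon bound to a double-bonded chain carbon. The same exchange was measured once, as a 2.2-fold lower number from compound 1 to compound 2 (0.34 log units; beyond the scatter), a lowering of modest size. The step of an at least 3.3-fold higher number from compound 1 to compound 3 (0.52 log units; beyond the scatter) shows how far compound 3 already sits beyond compound 1, its value resting at the limit of > 100000 nM in this assay, at which 1 of the 3 values shown sits. A modest lowering from the limit is therefore expected, so compound 4 may or may not return into the numbered range. The estimate for compound 4 is 100000 nM, expected between 40000 nM and 300000 nM. This means an expected step of a number no higher from compound 3 to compound 4 (the limit leaves the size open).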

Compound 4, half-maximal inhibitory concentration: > 100000 nM
Compound 4 ended at the assay's limit; the forecaster's own chance of this, stated with the estimate: 50%; the middle value sits exactly at the limit.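

With pentan-3-yl in place of 2-fluorophenyl, the acetoxymethyl exchange still gives an at least 7.2-fold higher number from compound 2 to compound 4 (0.86 log units; beyond the scatter), so the loss seen on the core of compound 1 recurs on a second core. The change therefore raises the number on both cores shown in this assay: the same change on two cores in this assay, an at least 3.3-fold higher number (0.52 log units; beyond the scatter) from compound 1 to compound 3 and an at least 7.2-fold higher number (0.86 log units; beyond the scatter) from compound 2 to compound 4; the limit leaves it open whether they differ. The pentan-3-yl step on the acetoxymethyl chain cannot be read, since compound 3 and compound 4 both rest at the assay's limit: the limit of > 100000 nM in this assay, at which 2 of the 4 values shown sit.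

On these data alone, how far the pentan-3-yl exchange moves the number on this chain stays open. Also open, as far as these compounds go, is whether a hydroxymethyl group or a carboxylic acid at this place would return a value inside the numbered range.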